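Aryl substituent change at the ring amine nitrogen

The source may report more compounds than this note shows. Statements on the series, on what has been measured and on what is new or still open speak of the compounds shown alone.

Two compounds in this series carry numbers. Compound 1 `CCCc1nc(-c2ccccc2)c(CNCCCN2CCN(c3ccccc3)CC2)o1` gives 43.7% in an assay on HEK293 cells for inhibition of Voltage-dependent T-type calcium channel subunit alpha-1G (Homo sapiens), read by fluorescence, tested at 10 uM; on this read-out lower numbers stand for less inhibition and higher numbers for more inhibition at the one concentration tested (going by the name of the read-out). Compound 2 `CCCc1nc(-c2ccccc2)c(CNCCN2CCN(c3ccc(Cl)cc3)CC2)o1` differs from compound 1 in more than one place; in this assay compound 2 gives 55.8%. This is the higher of the two numbers, and compound 1 sits lower by a gap that lies beyond the usual scatter. Within the data shown here, since no pair differs in only one place, no single change has a measured effect so far.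

Compound 3 `CCCc1nc(-c2ccccc2)c(CNCCN2CCN(c3ccccc3C)CC2)o1` is reached from compound 2 by one change, (2-methylphenyl in place of 4-chlorophenyl on an amine nitrogen in a ring). Nothing measured compares an aryl bearing chlorine with an aryl bearing a methyl group, so the direction rests on no shown step. A small downward step, or none beyond the scatter, is expected; the step of a number 9.8 percentage points lower from compound 2 to compound 3 (within the scatter) is estimated on that basis. Compound 3 is expected to give 46% in this assay, within a range from 26% to 66%.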

Compound 3, a percentage reported as inhibition, at one concentration (the size of the read-out at that concentration, not a potency): 51.3%
Estimate against measurement, compound 3: 5.3 percentage points below; measured number inside the range.
By their numbers in this assay, from the lowest: compounds 1, 3 and 2 (each within the scatter of the next, the first and the last beyond it).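

This gives the series its first comparison that differs in one place: in this assay, 2-methylphenyl in place of 4-chlorophenyl on the amine nitrogen in the ring gives a number 4.5 percentage points lower from compound 2 to compound 3 (within the scatter). At this position, then, the two substituted aryl groups are not told apart by this read-out, and a chlorine-bearing aryl is not required to keep the number within the scatter of compound 2. No measured information bears on the reason for this result.

A 2-chlorophenyl or 4-methylphenyl group on the same nitrogen would be needed to separate the identity of the substituent from its place on the aryl ring. Aryl groups such as 4-methoxyphenyl or a pyridine ring also remain open here, as does the effect of the chain length alone, since compound 1 differs from compound 2 and compound 3 in more than one place.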